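Replacing a benzyl sulfonamide with a cyclopentyl ethyl amine

The source may hold more compounds than are shown below. What is called first, only, known or untested is meant among the compounds shown, and "the series" means these compounds.

Within the data shown here, compound 2 `O=C(NCc1ccncc1)Nc1ccc(S(=O)(=O)NCc2ccccc2)cc1` gives 102 nM in an assay on isolated protein for activation of Nicotinamide phosphoribosyltransferase (Homo sapiens) (on this read-out lower numbers stand for an effect already at smaller amounts and higher numbers for an effect only at larger amounts of compound), the lower of the two numbers measured so far; compound 1 `O=C(NCc1ccncc1)Nc1ccc(S(=O)(=O)Nc2ccccc2)cc1` gives 410 nM. Compound 3 `CCN(C1CCCC1)S(=O)(=O)c1ccc(NC(=O)NCc2ccncc2)cc1` carries the change (cyclopentyl(ethyl)amino in place of benzylamino on a sulfonyl sulfur). Among the measured compounds shown here, the only measured step on this sulfonamide nitrogen is a 4.0-fold lower number from compound 1 to compound 2 (0.60 log units; beyond the scatter), but it concerns a different exchange and does not cover the loss of the aromatic ring or of the hydrogen-bond donor. With no direct guide, a step of a 2.5-fold higher number from compound 2 to compound 3 (0.39 log units; beyond the scatter) is expected, in either direction within a wide range. Compound 3 is estimated at 250 nM, between 60 nM and 1000 nM.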

Compound 3, half-maximal effective concentration: 60 nM
Estimate against measurement, compound 3: 4.2-fold (0.62 log units) above; low and high end bracket the measured number.
By their numbers in this assay, from the lowest: compounds 3 and 2 (each within the scatter of the next); then compound 1.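

A step of a 1.7-fold lower number from compound 2 to compound 3 (0.23 log units; within the scatter) shows that this position on the sulfonyl sulfur does not need the six-membered aromatic ring or the hydrogen-bond donor of benzylamino to keep a number of this size. The step of a 6.8-fold lower number from compound 1 to compound 3 (0.83 log units; beyond the scatter) places cyclopentyl(ethyl)amino clearly ahead of anilino. No measurement available here accounts for either step. Open, from the compounds shown here alone, is how much the ethyl group and the cyclopentyl ring each contribute. Going by these compounds, whether a smaller dimethylamino group or a larger cyclohexyl ring would give a similar number also remains open.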